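Swapping the cyclohexyl of compound 3 for a smaller cyclobutyl

The compounds below may be only part of what the source reports. "The series", "measured", "known", "first", "only" and "open" are said of these compounds alone.

Of the compounds shown here, three on a shared core have been tested in an assay on isolated protein for inhibition of protein kinase C delta type (Homo sapiens), read by TR-FRET, with a stated time of 2 h; a higher number here means a weaker inhibitor, a lower number a stronger inhibitor. Compound 3 `CC1(C)C[C@H](Nc2cc(NCc3cnccc3C(F)(F)F)ncc2C#N)CC[C@@H]1O` gives 500 nM, the lowest of the two numbers recorded. Compound 2 `CNC(=O)[C@H]1CC[C@@H](Nc2cc(NCc3cnccc3C(F)(F)F)ncc2C#N)CC1` gives 1600 nM, and the step of a 3.2-fold lower number from compound 2 to compound 3 (0.51 log units; beyond the scatter) is modest. Compound 1 `N#Cc1cnc(NCc2cnccc2C(F)(F)F)cc1NC[C@H]1C[C@H](O)C1` reaches only a limit of this assay, > 10000 nM (the limit of > 10000 nM in this assay, at which 1 of the 3 values shown sits). From there the step of an at least 20-fold lower number from compound 1 to compound 3 (1.30 log units; beyond the scatter) is large, and the step of an at least 6.2-fold lower number from compound 1 to compound 2 (0.79 log units; beyond the scatter) at least modest.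

Compound 4 `CC1(C)[C@@H](Nc2cc(NCc3cnccc3C(F)(F)F)ncc2C#N)C[C@@H]1C(N)=O` has not been measured. It differs from compound 3 by 3-carbamoyl-2,2-dimethylcyclobutyl in place of 4-hydroxy-3,3-dimethylcyclohexyl on a nitrogen on an aromatic ring. Within the data shown here, two measured steps bear on this: the change from a four-membered ring to a six-membered one in an at least 20-fold lower number from compound 1 to compound 3 (1.30 log units; beyond the scatter) lowered the number sharply, and the change from a carbamoyl to a hydroxy in a 3.2-fold lower number from compound 2 to compound 3 (0.51 log units; beyond the scatter) lowered it modestly. Compound 4 reverses both tendencies at once, so the number for compound 4 in this assay is expected to rise, with an estimated step of a 4.0-fold higher number from compound 3 to compound 4 (0.60 log units; beyond the scatter). Compound 4 is therefore estimated at 2000 nM, within a range from 500 nM to 8000 nM.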

Compound 4, half-maximal inhibitory concentration: > 10000 nM
Compound 4: only a limit was reported; the forecaster's own chance of this, stated with the estimate: 15%; at least 5.0-fold (0.69 log units) between middle value and limit.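

In this assay, the 3-carbamoyl-2,2-dimethylcyclobutyl group on this nitrogen gives an at least 20-fold higher number from compound 3 to compound 4 (1.30 log units; beyond the scatter), and it also gives an at least 6.2-fold higher number from compound 2 to compound 4 (0.79 log units; beyond the scatter). Compound 4 gives > 10000 nM, which is a limit of the assay, so a four-membered ring attached directly to the nitrogen fares no better here than the (3-hydroxycyclobutyl)methyl group, while both six-membered rings give readable values. The step between compound 1 and compound 4 cannot be read, and both of these compounds stand at the limit: the limit of > 10000 nM in this assay, at which 2 of the 4 values shown sit.

The change alters ring size and ring substituent together, and the compounds shown do not separate the two. From the compounds shown here alone, how a cyclopentyl ring would behave at this nitrogen, or an amine on the four-membered ring, remains open.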